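The compounds below may be only part of what the source reports. "The series", "measured", "known", "first", "only" and "open" are said of these compounds alone.

Measured compounds in a functional assay on PC-3 cells (Homo sapiens) for inhibition, with a stated time of 72 h; a higher number here means a weaker inhibitor, a lower number a stronger inhibitor:
Compound 1 `Cc1nc(-c2nc[nH]n2)ccc1-c1cnc2c(n1)N([C@H]1CC[C@@H](O)CC1)C(=O)CN2` gives 37 nM.
Compound 2 `Cc1nc(-c2nc[nH]n2)ccc1-c1cnc2c(n1)N(C1CCOCC1)C(=O)CN2` gives 102 nM.

For the measured compounds named here, compound 2 holds the higher of the two numbers in this assay, the only step to it being a 2.8-fold higher number from compound 1 to compound 2 (0.44 log units; beyond the scatter). Compound 3 `Cc1nc(-c2nc[nH]n2)ccc1-c1cnc2c(n1)N(CCC1CCOCC1)C(=O)CN2` differs from compound 2 by 2-(oxan-4-yl)ethyl in place of oxan-4-yl on an amide-type nitrogen in a ring. Going by the values given here, only one measured step touches this nitrogen, and it exchanged one ring for another rather than extending a chain, so it bears on the new step only loosely. A modest rise in the number is therefore expected, a 1.6-fold higher number from compound 2 to compound 3 (0.20 log units; within the scatter), though a step within the scatter cannot be excluded. Compound 3 is estimated at 160 nM, in the range 50 nM to 500 nM.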

Compound 3, half-maximal inhibitory concentration: 34 nM
Estimate against measurement, compound 3: 4.7-fold (0.67 log units) above, and the stated range ends above it.
By their numbers in this assay, from the lowest: compounds 3 and 1 (each within the scatter of the next); then compound 2.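

In this assay, extending from oxan-4-yl to 2-(oxan-4-yl)ethyl on the amide-type nitrogen gives a 3.0-fold lower number from compound 2 to compound 3 (0.48 log units; beyond the scatter) and shows that this position accepts the longer group, with the ring held away from the nitrogen by an ethyl link. Replacing 4-hydroxycyclohexyl with that group gives a 1.1-fold lower number from compound 1 to compound 3 (0.04 log units; within the scatter) and shows that a hydroxyl on a carbocyclic ring is not required for this level of inhibition. No supporting evidence is available to explain the gain from the ethyl link.

From the compounds shown here alone, whether a longer chain such as 3-(oxan-4-yl)propyl would hold this level remains open. So does the effect of a piperidine ring, with an amine in place of the ring oxygen, on the same ethyl link.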